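Replacing the aryl group on the aromatic nitrogen of compound 2

The source may hold more compounds than are shown below. What is called first, only, known or untested is meant among the compounds shown, and "the series" means these compounds.

Of the compounds shown here, two have been measured in a functional assay on MCF7 cells (Homo sapiens) for inhibition, read by MTT assay, with a stated time of 72 h (a lower number here means a stronger inhibitor, a higher number a weaker inhibitor), so far. Compound 1 `COc1cc2c(Oc3ccc(NC(=O)c4nn(-c5ccccc5C)cc(C)c4=O)c(F)c3)ccnc2cc1OCCCCCCC(=O)NO` gives 2690 nM and compound 2 `COc1cc2c(Oc3ccc(NC(=O)c4nn(-c5cccc(C(F)(F)F)c5)cc(C)c4=O)cc3)ccnc2cc1OCCCCCCC(=O)NO` gives 750 nM as the lower of the two numbers, with a gap beyond the usual scatter. For the measured compounds named here, compound 3 `COc1cc2c(Oc3ccc(NC(=O)c4nn(-c5ccccc5C)cc(C)c4=O)cc3)ccnc2cc1OCCCCCCC(=O)NO` has 2-methylphenyl in place of 3-(trifluoromethyl)phenyl on an aromatic nitrogen as its only change from compound 2. Going by the values given here, no measured pair isolates this change, so the expectation rests on thin evidence. Compound 1 also carries 2-methylphenyl but differs from compound 2 in another place too, and in this assay compound 1 stands at 2690 nM on the weaker side. A moderate move towards a higher number is therefore expected, near the edge of the scatter. The expected change is a 2.0-fold higher number from compound 2 to compound 3 (0.30 log units; within the scatter) and remains uncertain. For compound 3 the estimated value is 1500 nM with an expected range from 600 nM to 3800 nM in this assay.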

Compound 3, half-maximal inhibitory concentration: 1830 nM
Compound 3: middle estimate off by 1.2-fold (0.09 log units), on the low side; the range from low to high includes it.
By their numbers in this assay, from the lowest: compound 2; then compounds 3 and 1 (each within the scatter of the next).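

In this assay the step from 3-(trifluoromethyl)phenyl to 2-methylphenyl on the aromatic nitrogen can now be read on its own, as a 2.4-fold higher number from compound 2 to compound 3 (0.39 log units; beyond the scatter) with nothing else changed, so the number does respond to the aryl group at this position, though modestly. The same compound also isolates the other difference carried by compound 1: hydrogen in place of fluoro on an aromatic carbon gives a 1.5-fold lower number from compound 1 to compound 3 (0.17 log units; within the scatter) and so leaves no readable effect with 2-methylphenyl on the nitrogen. Nothing available offers a reason for either step.

The two aryl groups differ both in the substituent and in where it sits, and the compounds shown do not separate the two. From the compounds shown here alone, a plain phenyl, 3-methylphenyl or 2-(trifluoromethyl)phenyl on that nitrogen would address this, and whether fluoro stays without effect alongside 3-(trifluoromethyl)phenyl remains open.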